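Trifluoromethyl for methyl: compound 3 to compound 4

The compounds below may be only part of what the source reports. "The series", "measured", "known", "first", "only" and "open" are said of these compounds alone.

compound 1 `CCNc1cc(-c2ccc(NC(=O)Nc3ccc(C)cc3)cc2C)ccn1`: 22000 nM
compound 2 `CCNc1cc(-c2ccc(NC(=O)Nc3ccccc3Cl)cc2C)ccn1`: > 30000 nM (a limit, not a number)
compound 3 `CCNc1cc(-c2ccc(NC(=O)Nc3ccc(C)cc3)cc2C(F)(F)F)ccn1`: 27100 nM

In a functional assay on BT-483 cells (Homo sapiens) for cytotoxicity, read by MTT assay, with a stated time of 24 h (on this read-out lower numbers stand for stronger inhibition and higher numbers for weaker inhibition), compound 3 at 27100 nM lies within the scatter of compound 1 at 22000 nM and holds no distinct rank. Compound 4 `CCNc1cc(-c2ccc(NC(=O)Nc3ccc(C(F)(F)F)cc3)cc2C(F)(F)F)ccn1` follows from compound 3 by trifluoromethyl in place of methyl on an aromatic carbon in the change from 4-methylphenyl to 4-(trifluoromethyl)phenyl. Since the same exchange on another aromatic carbon gave a 1.2-fold higher number from compound 1 to compound 3 (0.09 log units; within the scatter) and 2-chlorophenyl in place of 4-methylphenyl gave an at least 1.3-fold higher number from compound 1 to compound 2 (0.13 log units; that floor lies within the scatter) no step beyond the scatter is expected in this assay in either direction. The expected change is a 1.0-fold lower number from compound 3 to compound 4 (0.02 log units; within the scatter) and no larger. Compound 4 is estimated at 26000 nM with an expected range of 12000 nM to 30000 nM on this read-out.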

Compound 4, half-maximal inhibitory concentration: 16400 nM
Estimate against measurement, compound 4: 1.6-fold (0.20 log units) above; the measured number falls inside the stated range.
By their numbers in this assay, from the lowest: compounds 4, 1 and 3 (each within the scatter of the next). At a limit, above all of these: compound 2.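

On the 4-methylphenyl group, trifluoromethyl in place of methyl gives a 1.7-fold lower number from compound 3 to compound 4 (0.22 log units; within the scatter) in this assay. The earlier compounds shown here held this exchange only on another aromatic carbon, with a 1.2-fold higher number from compound 1 to compound 3 (0.09 log units; within the scatter), so neither place now shows a step beyond the scatter. The upper end of the read-out is a limit in this set: the limit of > 30000 nM in this assay, at which 1 of the 4 values shown sits.

Still open, going by these compounds, is whether an amine or a carboxylic acid in place of trifluoromethyl on this phenyl group would move the number beyond the scatter.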